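Three Compounds at the Assay Limit, a Fourth Expected

This account rests on a few compounds, and the source may have more. Where it says the series, first, only, none or still open, it means among the compounds named here.

compound 1 `CCOC(=O)c1c(-c2cccc(-c3ccccc3)c2)[nH]c2cc(OC)ccc2c1=O`: > 22000 nM
compound 2 `CCOC(=O)c1c(-c2cccc(OC)c2)[nH]c2cc(OC)ccc2c1=O`: > 22000 nM
compound 3 `CCOC(=O)c1c(-c2cccc(-c3ccccc3)c2)[nH]c2cc(Cl)c(Cl)cc2c1=O`: > 22000 nM

In an ADME assay on HEK293 cells (Homo sapiens) for cytotoxicity, read by luminescence, with a stated time of 72 h (a lower number here means that less compound is needed, a higher number that more compound is needed for the effect), compound 1 gives > 22000 nM, which is a limit of the assay and not a number. Compound 2 gives > 22000 nM, likewise a limit. Compound 3 gives > 22000 nM, again a limit. Compound 2 differs from compound 1 by methoxy in place of phenyl on an aromatic carbon and the step is a step that the two limits leave unreadable from compound 1 to compound 2, as both values sit at the limit of > 22000 nM in this assay, at which 3 of the 3 values shown sit. The difference between the core of compound 1 and the core of compound 3 is not broken down here.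

Compound 4 `CCOC(=O)c1c(-c2cccc(OC)c2)[nH]c2cc(Cl)c(Cl)cc2c1=O` has not yet been measured in this assay. It differs from compound 3 by methoxy in place of phenyl on an aromatic carbon, the same change in the same place as that from compound 1 to compound 2. The step expected from compound 3 to compound 4 is estimated as a step that the limit leaves unreadable from compound 3 to compound 4, resting on a step that the two limits leave unreadable from compound 1 to compound 2 and on (the limit of > 22000 nM in this assay, at which 3 of the 3 values shown sit), which leave the size unreadable. Compound 4 is therefore expected to give about 30000 nM, with a range estimated from 15000 nM to 80000 nM.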

Compound 4, half-maximal effective concentration: > 22000 nM
Compound 4 gave a limit, no number; the forecaster's own chance of this, stated with the estimate: 85%; the middle value does not contradict the limit.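

In this assay compound 4 gives > 22000 nM, which is a limit of the assay and not a number. No step can be read between compound 3 and compound 4, as both sit at the same limit: the limit of > 22000 nM in this assay, at which 4 of the 4 values shown sit.

The compounds shown leave open whether phenyl and methoxy, or the cores of compound 1 and compound 3, differ at all in this assay.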